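A few compounds are considered here, and "the series" means these few. Any claim that something is new, unique, unknown or untested is made for them only; others in the source may bear on it.

Of the compounds shown here, two have so far been measured in a functional assay on DU-145 cells (Homo sapiens) for antiproliferative activity; a lower number here means a stronger inhibitor, a higher number a weaker inhibitor. Compound 1, `O=C(CCCCC[C@H](NC(=O)c1ccc(Br)cc1)C(=O)Nc1ccc(-c2ccccc2)cc1)NO`, gives 149 nM in this assay. Compound 2, `CN(C)c1ccc(C(=O)N[C@@H](CCCCCC(=O)NO)C(=O)Nc2cccc3cccnc23)cc1`, gives 61 nM in this assay. Of these two numbers, compound 2 has the lower one, and its gap to compound 1 lies beyond the usual scatter of this kind of measurement.

Compound 3, `O=C(/C=C/c1ccccc1)N[C@@H](CCCCCC(=O)NO)C(=O)Nc1cccc2cccnc12`, has not yet been measured in this assay. It differs from compound 2 in one place: 2-phenylethenyl in place of 4-(dimethylamino)phenyl on a carbonyl carbon. The change sits on a carbonyl carbon whose other neighbour is an amide-type nitrogen, and the rest of the structure is kept. Within the data shown here, no measured pair shows this same change, so its direction cannot be read from the data. A step of modest size is expected, a little more likely toward a higher number than a lower one. The step from compound 2 to compound 3 is expected to be a 1.5-fold higher number from compound 2 to compound 3 (0.17 log units; within the scatter). Compound 3 is expected to give about 90 nM in this assay, within a range from 40 nM to 220 nM.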

Compound 3, half-maximal inhibitory concentration: 30 nM
For compound 3 the middle estimate is 3.0-fold (0.48 log units) above the measured one, and the stated range ends above it.
By their numbers in this assay, from the lowest: compound 3; then compound 2; then compound 1.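

In this assay the place on the carbonyl carbon whose other neighbour is an amide-type nitrogen proves sensitive to the group it carries: replacing 4-(dimethylamino)phenyl with 2-phenylethenyl gives a 2.0-fold lower number from compound 2 to compound 3 (0.31 log units; beyond the scatter) and this modest step lies beyond the scatter. In this pair, the lower number comes with a group that has no nitrogen and has one double bond outside aromatic rings, so the dimethylamino nitrogen is not required for activity at this level. No measurement available here explains the direction of the step.

The compounds shown do not separate the role of the double bond from that of the phenyl ring, which a saturated 2-phenylethyl group or an unsubstituted phenyl group could test. They also leave open whether the same change would lower the number on the core of compound 1.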